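This account rests on a few compounds, and the source may have more. Where it says the series, first, only, none or still open, it means among the compounds named here.

Measured so far:
- compound 1, `COc1ccccc1-c1ccc2ncn(-c3cc(OC)c(OC)c(OC)c3)c2c1`: 5050 nM
- compound 2, `COc1cc(-n2cnc3ccc(-c4cccc([N+](=O)[O-])c4)cc32)cc(OC)c1OC`: 380 nM
- compound 3, `COc1ccc(-c2ccc3ncn(-c4cc(OC)c(OC)c(OC)c4)c3c2)cc1F`: 430 nM

These three compounds share one core and differ only in the aryl group attached to it. In a functional assay on SGC-7901 cells (Homo sapiens) for antiproliferative activity, read by MTT assay, with a stated time of 72 h (a higher number here means a weaker inhibitor, a lower number a stronger inhibitor), compound 3 gives 430 nM, which puts it second highest of the three numbers; its nearest neighbour is compound 2, and the gap a 1.1-fold higher number from compound 2 to compound 3 (0.05 log units; within the scatter) is too small to separate them, while compound 1 sits far away, with a 12-fold lower number from compound 1 to compound 3 (1.07 log units; beyond the scatter).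

Compound 4, `COc1cc(-n2cnc3ccc(-c4ccc(Cl)cc4Cl)cc32)cc(OC)c1OC`, is the next step from compound 3. The change is 2,4-dichlorophenyl in place of 3-fluoro-4-methoxyphenyl on an aromatic carbon.

Among the measured compounds shown here, no measured step swaps exactly these two groups, so the prediction rests on the pattern of the three aryl groups seen. Both a 13-fold lower number from compound 1 to compound 2 (1.12 log units; beyond the scatter) and a 12-fold lower number from compound 1 to compound 3 (1.07 log units; beyond the scatter) show that moving away from 2-methoxyphenyl gave large drops in the number, whereas the two replacements hardly differ from each other. The entering 2,4-dichlorophenyl is a new type of group, and its substitution pattern partly echoes the 2-methoxyphenyl of compound 1, which gave the highest number. On balance a moderate rise in the number is expected, a 3.5-fold higher number from compound 3 to compound 4 (0.54 log units; beyond the scatter), with wide uncertainty. Compound 4 is therefore estimated at 1500 nM, in the range 400 nM to 6000 nM.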

Compound 4, half-maximal inhibitory concentration: > 10000 nM
Compound 4: a limit, no number (the forecaster's own chance of this, stated with the estimate: 5%); middle value at least 6.6-fold (0.82 log units) from the limit.
By their numbers in this assay, from the lowest: compounds 2 and 3 (each within the scatter of the next); then compound 1. At a limit, above all of these: compound 4.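

In this assay compound 4 gives > 10000 nM, which is a limit of the assay and not a number. Among the compounds shown here, this shows that the position does not accept every aryl group alike, since 2,4-dichlorophenyl, the first group here to carry chlorine, brings an at least 23-fold higher number from compound 3 to compound 4 (1.36 log units; beyond the scatter) and an at least 26-fold higher number from compound 2 to compound 4 (1.42 log units; beyond the scatter), even though 3-nitrophenyl and 3-fluoro-4-methoxyphenyl could not be told apart. The comparison with the 2-methoxyphenyl group is less decisive, with an at least 1.9-fold higher number from compound 1 to compound 4 (0.29 log units; that floor lies within the scatter), so compound 4 cannot be ranked against compound 1, yet across the four compounds the two groups with a substituent numbered 2 give the two highest readings, and no compound shown goes against this.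

On these data alone, what remains open is whether the weak result follows the substituent numbered 2, the one numbered 4, or only the two chlorines together, and a 2-chlorophenyl or a 4-chlorophenyl group would help to separate these possibilities. As far as these compounds go, it is also open whether a group of a different kind on this aryl ring, such as an amine or a carboxylic acid, would fit the same pattern.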